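From chloro to bromo on the weakest measured compound

The source may report more compounds than this note shows. Statements on the series, on what has been measured and on what is new or still open speak of the compounds shown alone.

Measured so far in a functional assay on HCT-116 cells (Homo sapiens) for antiproliferative activity, read by MTT assay, with a stated time of 48 h; on this read-out lower numbers stand for stronger inhibition and higher numbers for weaker inhibition:
- compound 1 `COc1ccc(CN(C(=O)CSc2nc3ccccc3s2)c2cc(OC)c(OC)c(OC)c2)cc1O` gives 182 nM
- compound 2 `COc1cc(CN(C(=O)CSc2nc3ccccc3s2)c2cc(OC)c(OC)c(OC)c2)cc(OC)c1OC` gives 65300 nM
- compound 3 `COc1cc(N(Cc2ccc(Cl)cc2)C(=O)CSc2nc3ccccc3s2)cc(OC)c1OC` gives 603000 nM

Compound 3 stands at the weak end of this small set, and its 603000 nM is the highest of the three numbers. Compound 4 `COc1cc(N(Cc2ccc(Br)cc2)C(=O)CSc2nc3ccccc3s2)cc(OC)c1OC` has bromo in place of chloro on an aromatic carbon, para to a large group, and the change counts as bromo in place of chloro on an aromatic carbon with the rest of the structure shared. Within the data shown here, no measured step tests this swap directly. The nearest evidence comes from replacing the whole aromatic group on the same saturated chain carbon: a 3300-fold higher number from compound 1 to compound 3 (3.52 log units; beyond the scatter) was large, a 9.2-fold higher number from compound 2 to compound 3 (0.97 log units; beyond the scatter) was modest and a 360-fold higher number from compound 1 to compound 2 (2.55 log units; beyond the scatter) was large. Each of those exchanges altered far more of the molecule than one halogen atom, so they say little about the size of this step, though they do argue for a wide range. In this assay the expected result is a 1.2-fold lower number from compound 3 to compound 4 (0.08 log units; within the scatter) and thus no shift beyond the scatter in either direction. For compound 4 the estimated value is 500000 nM with an expected range from 100000 nM to 1500000 nM in repeated measurements.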

Compound 4, half-maximal inhibitory concentration: 63800 nM
Compound 4: middle estimate off by 7.8-fold (0.89 log units), on the high side; measured number outside the range, below it.
By their numbers in this assay, from the lowest: compound 1; then compounds 4 and 2 (each within the scatter of the next); then compound 3.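

In this assay, a single halogen atom at this place on the benzyl group makes a clear difference: bromo in place of chloro, with no ring, hydrogen-bond donor or acceptor gained or lost, gives a step (a 9.5-fold lower number from compound 3 to compound 4 (0.98 log units; beyond the scatter)) about the size of an earlier exchange of one whole aromatic group for another (a 9.2-fold higher number from compound 2 to compound 3 (0.97 log units; beyond the scatter)). The 4-bromophenyl and 3,4,5-trimethoxyphenyl groups now stand level within the scatter (a 1.0-fold lower number from compound 2 to compound 4 (0.01 log units; within the scatter)), while a wide gap remains to the 3-hydroxy-4-methoxyphenyl group (a 350-fold higher number from compound 1 to compound 4 (2.54 log units; beyond the scatter)). Nothing available explains why these two halogens differ here.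

As far as these compounds go, whether the trend continues to iodo, and what fluoro, methyl or nitrile would give at this place, remains open. Also open, from the compounds shown here alone, is whether adding bromo to the 3-hydroxy-4-methoxyphenyl group would change the number for compound 1.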